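The compounds below may be only part of what the source reports. "The series", "measured", "known", "first", "only" and "open" are said of these compounds alone.

The measured compounds in a functional assay on MT4 cells (Homo sapiens) for cytotoxicity, read by MTT assay; a higher number here means that more compound is tolerated, a lower number that less compound is tolerated:
Compound 1 `Cc1c(O)nc(SCc2ccc(O)cc2)nc1Cc1c(Cl)cccc1Cl` gives 41000 nM.
Compound 2 `Cc1c(O)nc(SCc2ccccc2)nc1Cc1c(Cl)cccc1Cl` gives only a limit of the assay, > 64000 nM.
Compound 3 `Cc1c(O)nc(SCc2cccc(Cl)c2)nc1Cc1c(Cl)cccc1Cl` gives only a limit of the assay, > 59000 nM.

Compound 3 therefore stands at the top of the tested range, where its value is a limit rather than a number, as the limit of > 59000 nM in this assay, at which 1 of the 3 values shown sits, records. Compound 2 stands at a comparable limit, (the limit of > 64000 nM in this assay, at which 1 of the 3 values shown sits). Among the shown numbers, only compound 1 gives a true value, and it lies somewhat lower.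

Compound 4 `Cc1c(O)nc(SCc2cccc(F)c2)nc1Cc1c(Cl)cccc1Cl` differs from compound 3 in one place:
fluoro in place of chloro on an aromatic carbon

Among the measured compounds shown here, two measured steps bear on this. The step that the two limits leave unreadable from compound 2 to compound 3 is the closest comparison, since it changes the same aromatic carbon, but its size cannot be read because both ends are limits. The step of an at least 1.4-fold higher number from compound 1 to compound 3 (0.15 log units; that floor lies within the scatter) has a floor that lies within the scatter. Nothing shown points to a change beyond the scatter, and compound 3 already sits at a limit of this assay.

Compound 4 is therefore expected to give a step that the limit leaves unreadable from compound 3 to compound 4, meaning no change beyond the scatter, with an estimated value of 60000 nM, ranging from 35000 nM to 100000 nM, and quite possibly reported again only as a limit.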

Compound 4, half-maximal cytotoxic concentration: > 61000 nM
Compound 4 was reported as a limit (the forecaster's own chance of this, stated with the estimate: 60%); at least 1.0-fold (0.00 log units) between middle value and limit.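

Compound 4 is reported only as a limit in this assay, the third compound shown to be reported this way: the limit of > 61000 nM in this assay, at which 1 of the 4 values shown sits. Fluoro on this aromatic carbon, meta to a large group, therefore gives no true value, just as chloro and hydrogen give none there, and the steps to compound 4 from compound 2 and from compound 3 cannot be read. Among the compounds shown here, the one readable comparison gives an at least 1.4-fold higher number from compound 1 to compound 4 (0.17 log units; that floor lies within the scatter) and so does not establish a change beyond the scatter.

The compounds shown leave open where the true values of compound 2, compound 3 and compound 4 lie, so chloro, fluoro and hydrogen cannot be ranked at this position. They also leave open whether an amine or a carboxylic acid on the same aromatic carbon would give a value that can be read.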